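From Ethoxy to Isopropoxy: One More Methyl

The compounds below may be only part of what the source reports. "The series", "measured", "known", "first", "only" and "open" are said of these compounds alone.

In a functional assay on the whole organism (strain Sprague-Dawley) for inhibition, with Rattus norvegicus as the target, with a stated time of 10 min (on this read-out lower numbers stand for an effect already at smaller amounts and higher numbers for an effect only at larger amounts of compound), compound 1 (`CCOC(=O)c1cnc(-c2ccccc2F)[nH]c1=O`) gives > 10 mg/kg, which is a limit and not a number. Compound 2 (`CCOC(=O)c1cnc(-c2ccccc2OC)[nH]c1=O`) gives 10 mg/kg. Compound 3 (`CCOC(=O)c1cnc(-c2ccccc2OCC)[nH]c1=O`) gives 2 mg/kg, the lower of the two actual numbers. Compound 4 (`CCOC(=O)c1cnc(-c2ccccc2OC(C)C)[nH]c1=O`) turns ethoxy into isopropoxy: methyl in place of hydrogen on a saturated chain carbon bound to an oxygen on an aromatic ring and a saturated chain carbon. Among the measured compounds shown here, the closest precedent is a 5.0-fold lower number from compound 2 to compound 3 (0.70 log units; beyond the scatter), also a methyl in place of hydrogen on the chain carbon bound to oxygen, and beyond the scatter. The step of an at least 5.0-fold lower number from compound 1 to compound 3 (0.69 log units; beyond the scatter) points the same way. With one close precedent, only a small further fall, within the scatter, is expected in this assay. The estimate is a 1.3-fold lower number from compound 3 to compound 4 (0.12 log units; within the scatter). Compound 4 is expected at 1.5 mg/kg, within an estimated range of 0.5 mg/kg to 5 mg/kg.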

Compound 4, dose for 50% inhibition: 2 mg/kg
Compound 4: the middle estimate sits 1.3-fold (0.12 log units) below what was measured, and the stated range covers the measured number.
By their numbers in this assay, from the lowest: compounds 3 and 4 (each within the scatter of the next); then compound 2.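

In this assay one more methyl on the ethoxy group gives no change at the digits printed from compound 3 to compound 4 (within the scatter) and so the fall seen from methoxy to ethoxy does not carry on to isopropoxy. Isopropoxy keeps that earlier fall: isopropyl in place of methyl on the oxygen gives a 5.0-fold lower number from compound 2 to compound 4 (0.70 log units; beyond the scatter) in this small series. From the compounds shown here alone, the step of an at least 5.0-fold lower number from compound 1 to compound 4 (0.69 log units; beyond the scatter) rests on a limit for compound 1 and its size stays open: the limit of > 10 mg/kg in this assay, at which 1 of the 4 values shown sits.

Going by these compounds, whether a longer chain such as butoxy or a ring such as cyclopentyloxy would hold this level stays open. So does the effect of an amine on the chain.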